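A Thiophene Replaces the Fluoro-Methoxyphenyl Arm

The source may report more compounds than this note shows. Statements on the series, on what has been measured and on what is new or still open speak of the compounds shown alone.

Compound 1 `COc1ccc(-c2nc3cccc(-c4cc(OC)c(OC)c(OC)c4)c3o2)cc1F`: 2800 nM
Compound 2 `COc1cc(-c2cccc3nc(-c4cccc(C)c4)oc23)cc(OC)c1OC`: > 25000 nM
Compound 3 `COc1cc(-c2cccc3nc(-c4ccc(N)cc4)oc23)cc(OC)c1OC`: 310 nM

Three compounds share one core and differ only in the aryl group attached to it. In a functional assay on NCI-H460 cells (Homo sapiens) for antiproliferative activity, read by MTT assay, with a stated time of 48 h (on this read-out lower numbers stand for stronger inhibition and higher numbers for weaker inhibition), compound 1 gives 2800 nM. Compound 3, bearing a 4-aminophenyl, gives 310 nM. For compound 2, with a 3-methylphenyl, the assay reports only a limit, > 25000 nM (the limit of > 25000 nM in this assay, at which 1 of the 3 values shown sits). Among the numbers shown, compound 1 therefore stands as the higher of the two, while compound 2 sits at the limit.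

Compound 4 `COc1cc(-c2cccc3nc(-c4cccs4)oc23)cc(OC)c1OC` has not yet been measured. It differs from compound 1 as follows: thiophen-2-yl in place of 3-fluoro-4-methoxyphenyl on an aromatic carbon. For the measured compounds named here, two measured steps touch the same position: an at least 8.9-fold higher number from compound 1 to compound 2 (0.95 log units; beyond the scatter) and a 9.0-fold lower number from compound 1 to compound 3 (0.96 log units; beyond the scatter). Going by the values given here, the thiophen-2-yl carries no amino group, and the closest precedent is compound 2, whose 3-methylphenyl left the number at the assay limit. A weakening step in this assay is therefore expected. Compound 4 is estimated at 8000 nM, with a range from 2000 nM to 30000 nM, corresponding to a 2.9-fold higher number from compound 1 to compound 4 (0.46 log units; beyond the scatter).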

Compound 4, half-maximal inhibitory concentration: 1600 nM
Estimate against measurement, compound 4: 5.0-fold (0.70 log units) above; the measured number lies below the stated range.
By their numbers in this assay, from the lowest: compound 3; then compounds 4 and 1 (each within the scatter of the next). At a limit, above all of these: compound 2.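

The thiophen-2-yl shows that the aryl group at this position can shrink from 9 heavy atoms to 5 without a change that can be told from scatter, a 1.8-fold lower number from compound 1 to compound 4 (0.24 log units; within the scatter), though the 4-aminophenyl keeps its lead, a 5.2-fold higher number from compound 3 to compound 4 (0.71 log units; beyond the scatter). Lacking an amino group therefore does not in itself put a compound at the limit of this assay, as the thiophen-2-yl stands well clear of the 3-methylphenyl, an at least 15-fold lower number from compound 2 to compound 4 (1.19 log units; beyond the scatter). The entry for compound 2 is a limit and not a number: the limit of > 25000 nM in this assay, at which 1 of the 4 values shown sits.

Going by these compounds, what remains open is how a 3-aminophenyl or a 4-hydroxyphenyl would read at this position. Also open, on these data alone, is whether an amine on the thiophen-2-yl would bring it to the level of compound 3, and how a furan-2-yl would compare with the thiophen-2-yl.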